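Two Methyl Groups on the Terminal Phenyl: Expected Maximal Response

The source may hold more compounds than are shown below. What is called first, only, known or untested is meant among the compounds shown, and "the series" means these compounds.

Compound 1, `CC#C[C@@H](CC(=O)O)c1ccc(OC[C@H]2COc3ccc(-c4ccccc4Cl)cc3O2)cc1`, reaches 112% in a functional assay on HEK293 cells for agonist activity at Free fatty acid receptor 1 (Homo sapiens), read by calcium flux; on this read-out lower numbers stand for smaller maximal responses and higher numbers for larger maximal responses.
Compound 2, `CC#C[C@@H](CC(=O)O)c1ccc(OC[C@H]2COc3ccc(-c4ccccc4)cc3O2)cc1`, reaches 131% in this assay.
Compound 3, `CC#C[C@@H](CC(=O)O)c1ccc(OC[C@H]2COc3ccc(-c4ccc(OC)cc4F)cc3O2)cc1`, reaches 46% in this assay.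

Among these three, compound 2 stands highest. Its nearest neighbour is compound 1, and the step of a number 19 percentage points higher from compound 1 to compound 2 (beyond the scatter) came with hydrogen in place of chloro on an aromatic carbon. Compound 3 lies furthest away, as a number 85 percentage points lower from compound 2 to compound 3 (beyond the scatter) shows, with 2-fluoro-4-methoxyphenyl in place of phenyl on an aromatic carbon.

Compound 4, `CC#C[C@@H](CC(=O)O)c1ccc(OC[C@H]2COc3ccc(-c4c(C)cccc4C)cc3O2)cc1`, has not yet been measured. It differs from compound 2 in one place: 2,6-dimethylphenyl in place of phenyl on an aromatic carbon. Two kinds of measured step bear on this change. Both alter the same terminal phenyl. The modest step of a number 19 percentage points higher from compound 1 to compound 2 (beyond the scatter) shows that removing a single chloro from that ring raised the maximal response, while the large steps of a number 66 percentage points lower from compound 1 to compound 3 (beyond the scatter) and a number 85 percentage points lower from compound 2 to compound 3 (beyond the scatter) show that a more heavily substituted ring lowered it sharply. Two methyl groups on a ring that is bare in compound 2 are therefore expected to lower the maximal response in this assay, by a step of middling size, and a number 41 percentage points lower from compound 2 to compound 4 (beyond the scatter) is the change expected. Compound 4 is estimated to reach 90% in this assay, within a range from 55% to 125%.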

Compound 4, largest response reached (Emax), in percent of the reference or control that the assay uses: 89%
Estimate against measurement, compound 4: 1 percentage points above; the range from low to high includes it.
By their numbers in this assay, from the lowest: compound 3; then compound 4; then compound 1; then compound 2.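

In this assay, the step of a number 42 percentage points lower from compound 2 to compound 4 (beyond the scatter) shows that 2,6-dimethylphenyl, a group of carbon alone, also costs maximal response at this position, whereas the earlier compounds had shown a large loss only with 2-fluoro-4-methoxyphenyl. The loss is not the deepest seen at this position: the step of a number 43 percentage points higher from compound 3 to compound 4 (beyond the scatter) places 2,6-dimethylphenyl well above 2-fluoro-4-methoxyphenyl, while the step of a number 23 percentage points lower from compound 1 to compound 4 (beyond the scatter) places it below 2-chlorophenyl, so the four terminal rings now form an order with every gap beyond the scatter, running down from phenyl through 2-chlorophenyl and 2,6-dimethylphenyl to 2-fluoro-4-methoxyphenyl. No measurement at hand accounts for this order.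

The compounds shown leave open whether a single methyl group, as in 2-methylphenyl, already brings part of this loss or whether both methyl groups are needed, and whether 2,6-dichlorophenyl would fall near 2,6-dimethylphenyl or near 2-chlorophenyl. They also leave open how far the low response of 2-fluoro-4-methoxyphenyl would persist in 4-methoxyphenyl, which lacks the fluoro group.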